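The source may hold more compounds than are shown below. What is called first, only, known or untested is meant among the compounds shown, and "the series" means these compounds.

Compound 1 `COC(=O)c1cccc(N/C(=N/[C@@H]2c3cc(C#N)ccc3OC(C)(C)[C@H]2O)NC#N)c1` gives 4100 nM in a functional assay (aorta) with Rattus norvegicus as the target; a lower number here means a stronger inhibitor, a higher number a weaker inhibitor. Compound 2 `CC1(C)Oc2ccc(C#N)cc2[C@@H](/N=C(\NC#N)Nc2ccc(C(=O)O)cc2)[C@@H]1O` gives > 100000 nM in this assay, which is a limit of the assay and not a number.

Compound 2 therefore stands at the weak end of the two measured compounds, at the limit of > 100000 nM in this assay, at which 1 of the 2 values shown sits. Going by the values given here, the single measured step, an at least 24-fold higher number from compound 1 to compound 2 (1.38 log units; beyond the scatter), is large and beyond the scatter, and it was brought about by 4-carboxyphenyl in place of 3-(methoxycarbonyl)phenyl on an amine nitrogen. Compound 3 `CC1(C)Oc2ccc(C#N)cc2[C@@H](/N=C(\NC#N)Nc2ccc3c(c2)CCC3)[C@@H]1O` is not yet measured. It differs from compound 2 by 2,3-dihydro-1H-inden-5-yl in place of 4-carboxyphenyl on an amine nitrogen. Among the compounds with values here, of the measured steps, only the one from compound 1 to compound 2 bears on this change, since it is the 4-carboxyphenyl group that is taken away again; the group that arrives carries no hydrogen-bond donor or acceptor, so the new compound resembles neither measured compound closely. A step back toward lower numbers in this assay is expected, though its size is uncertain because compound 2 sits at the limit > 100000 nM. The expected step is an at least 16-fold lower number from compound 2 to compound 3 (1.22 log units; beyond the scatter). Compound 3 is estimated at 6000 nM, with a range from 800 nM to 60000 nM.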

Compound 3, half-maximal inhibitory concentration: 41300 nM
For compound 3 the middle estimate is 6.9-fold (0.84 log units) below the measured one, and the stated range covers the measured number.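

At this amine nitrogen, 2,3-dihydro-1H-inden-5-yl in place of 4-carboxyphenyl gives an at least 2.4-fold lower number from compound 2 to compound 3 (0.38 log units; beyond the scatter) in this assay, so a group with 0 hydrogen-bond donors and 0 hydrogen-bond acceptors brings the read-out to a measured number. Compound 2 remains a limit of the assay and not a number, so that step has only a lower bound: the limit of > 100000 nM in this assay, at which 1 of the 3 values shown sits. Losing the 4-carboxyphenyl group does not by itself recover the level of compound 1, as the carbon-only group still leaves a 10-fold higher number from compound 1 to compound 3 (1.00 log units; beyond the scatter), and so compound 1 keeps the lowest number of the three.

The compounds shown leave open what sets compound 1 apart, since the 3-(methoxycarbonyl)phenyl group is the only one here with an ester, and the comparisons cannot separate the ester from its place on the ring. From the compounds shown here alone, how a primary amide, a hydroxyl or a methoxy group on the phenyl ring would read in this assay also stays open, as does the true size of the step from the limit.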